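A few compounds are considered here, and "the series" means these few. Any claim that something is new, unique, unknown or untested is made for them only; others in the source may bear on it.

Measured so far in an ADME assay on MT4 cells (Homo sapiens) for cytotoxicity, read by MTT assay, with a stated time of 4 days; a higher number here means that more compound is tolerated, a lower number that less compound is tolerated:
- compound 1 `CCOC(=O)c1cnc(N2CCN(Cc3cccc(C#N)c3)CC2)nc1Oc1c(C)cc(-c2ccc(C#N)cc2)cc1C` gives > 125000 nM, a limit of the assay.
- compound 2 `CCOC(=O)c1cnc(N2CCN(Cc3cccc(F)c3)CC2)nc1Oc1c(C)cc(-c2ccc(C#N)cc2)cc1C` gives > 125000 nM, a limit of the assay.
- compound 3 `CCOC(=O)c1cnc(N2CCN(Cc3cccc(Br)c3)CC2)nc1Oc1c(C)cc(-c2ccc(C#N)cc2)cc1C` gives > 125000 nM, a limit of the assay.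

Compound 3 thus stands only at a limit in this assay, and the two other values shown are limits as well. The steps a step that the two limits leave unreadable from compound 1 to compound 2, a step that the two limits leave unreadable from compound 1 to compound 3 and a step that the two limits leave unreadable from compound 2 to compound 3 cannot be sized, because every value sits at the limit of > 125000 nM in this assay, at which 3 of the 3 values shown sit. Among the compounds with values here, nothing among the measured pairs therefore reads as a step of any size or direction.

The next compound, compound 4 `CCOC(=O)c1cnc(N2CCN(Cc3ccc(S(C)(=O)=O)cc3)CC2)nc1Oc1c(C)cc(-c2ccc(C#N)cc2)cc1C`, differs from compound 3 as follows: 4-(methylsulfonyl)phenyl in place of 3-bromophenyl on a saturated chain carbon bound to an amine nitrogen in a ring. Within the data shown here, the three measured variations of the benzyl substituent on the piperazine all left the read-out at the limit, so no measured step bears on this change beyond showing that such substituent swaps have not produced a readable number. The step of a number no higher from compound 3 to compound 4 (the limit leaves the size open) is accordingly expected to be unreadable as well. Compound 4 is estimated at 125000 nM, with a range from 60000 nM to 250000 nM, most probably reported again as a limit.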

Compound 4, half-maximal cytotoxic concentration: > 125000 nM
Compound 4: no number, only a limit; the forecaster's own chance of this, stated with the estimate: 85%; the middle value sits exactly at the limit.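

Compound 4 adds no readable step against compound 1, compound 2 or compound 3 in this assay, because all four compounds stand at the same limit: the limit of > 125000 nM in this assay, at which 4 of the 4 values shown sit.

The compounds shown leave open whether any of these benzyl substituents changes the tolerated concentration at all, as none gives a number.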